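The compounds below may be only part of what the source reports. "The series", "measured", "known", "first", "only" and "open" are said of these compounds alone.

Three measured compounds share one core and differ only in the group attached to it. In an in vitro assay on HEK385-7 cells for displacement of a labelled ligand from prostaglandin D2 receptor 2 (Homo sapiens) (a higher number here means a weaker inhibitor, a lower number a stronger inhibitor), compound 1 `O=C(O)Cc1sc(CS(=O)(=O)c2ccc(Cl)cc2)nc1-c1ccc(Cl)cc1` gives 1500 nM. Compound 2 `O=C(O)Cc1sc(C(c2ccccc2)c2ccc(F)cc2)nc1-c1ccc(Cl)cc1` gives 17 nM in this assay, and compound 3 `O=C(O)Cc1sc(C(c2ccc(F)cc2)c2ccc(F)cc2)nc1-c1ccc(Cl)cc1` gives 9.7 nM, the lowest number of the three, though the step of a 1.8-fold lower number from compound 2 to compound 3 (0.24 log units; within the scatter) lies within the scatter; only the gap to compound 1 is beyond it. Compound 4 `NS(=O)(=O)c1ccc(-c2nc(C(c3ccc(F)cc3)c3ccc(F)cc3)sc2CC(=O)O)cc1` differs from compound 3 by sulfamoyl in place of chloro on an aromatic carbon. Among the measured compounds shown here, no measured step touches this part of the molecule: the single known step, a 1.8-fold lower number from compound 2 to compound 3 (0.24 log units; within the scatter), concerns another position, and compound 1 differs elsewhere again. Without guidance, a small loss is the expected outcome, a step of a 3.1-fold higher number from compound 3 to compound 4 (0.49 log units; beyond the scatter). Compound 4 is therefore estimated at 30 nM, within a range from 8 nM to 120 nM.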

Compound 4, half-maximal inhibitory concentration: 1500 nM
Beside the measured number, compound 4's estimate is 50-fold (1.70 log units) below it, and the stated range ends below it.
By their numbers in this assay, from the lowest: compounds 3 and 2 (each within the scatter of the next); then compounds 1 and 4 (each within the scatter of the next).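

In this assay the change from 4-chlorophenyl to 4-sulfamoylphenyl brings a 150-fold higher number from compound 3 to compound 4 (2.19 log units; beyond the scatter) and so shows that the group on this aromatic ring matters strongly for the measured number. Among the compounds shown here, the earlier compounds could not show this, since the one earlier step concerned another position and lay within the scatter. Nothing at hand explains the size of this loss. With only chloro and sulfamoyl shown at this position, it stays open whether the loss belongs to sulfamoyl alone. A methyl, a methoxy or a nitrile there could give quite different numbers.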